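Lengthening the Chain on Compound 2

A few compounds are considered here, and "the series" means these few. Any claim that something is new, unique, unknown or untested is made for them only; others in the source may bear on it.

- compound 1 `CCCCC(CCO)n1cnc2c(Cl)nc(F)nc21` gives 13200 nM
- compound 2 `CCCCC(CCO)n1cnc2c(Cl)nc(Cl)nc21` gives 30900 nM

Going by the values given here, in a functional assay on SW480 cells (Homo sapiens) for antiproliferative activity, read by MTT assay, with a stated time of 48 h (a lower number here means a stronger inhibitor, a higher number a weaker inhibitor), compound 2 gives 30900 nM as the higher of the two numbers so far, and its only neighbour, compound 1, gives 13200 nM as the lower one. The next compound is compound 3 `CCCCCCCC(CCO)n1cnc2c(Cl)nc(Cl)nc21` which keeps the core of compound 2. The change is propyl in place of hydrogen on a saturated chain carbon, five bonds along the chain from an aromatic nitrogen and nothing else in the structure differs.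

Among the compounds with values here, the only measured step is a 2.3-fold higher number from compound 1 to compound 2 (0.37 log units; beyond the scatter) and it is a modest one made on an aromatic carbon, not on the chain. Within the data shown here, no measured pair varies the chain, so the data fix neither the size nor the direction of this new step. Using that one modest step as a rough yardstick, a step of similar size is expected, with a tentative lean toward a lower number and a wide margin in both directions. The expected step is a 2.2-fold lower number from compound 2 to compound 3 (0.34 log units; beyond the scatter) and it remains an estimate. For compound 3 the estimated value is 14000 nM with an expected range from 4500 nM to 40000 nM in this assay as the test still to come.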

Compound 3, half-maximal inhibitory concentration: 13600 nM
Estimate against measurement, compound 3: 1.0-fold (0.01 log units) above, within the range that was stated.
By their numbers in this assay, from the lowest: compounds 1 and 3 (each within the scatter of the next); then compound 2.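

In this assay, the saturated chain now has a measured step of its own, a 2.3-fold lower number from compound 2 to compound 3 (0.36 log units; beyond the scatter), whereas the earlier step was made on an aromatic carbon. Putting propyl in place of hydrogen, five bonds along the chain from an aromatic nitrogen, therefore moves this pair toward the stronger-inhibitor side of the scale, though the step is only modest and it lies beyond the usual scatter of repeated measurements. Nothing available explains why this change lowers the number, so the step stands as an observation without a known cause.

A single step cannot show whether the number depends steadily on chain length, or whether a shorter addition such as methyl or a longer chain such as hexyl would lower it further or raise it again. It also leaves open whether an amine or a carboxylic acid at this place would give a similar step, and whether propyl would have the same effect on compound 1, which carries fluoro in place of chloro on the aromatic carbon.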